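Notes on the hydrazone series: methyl removal from the aryl ring

The compounds below may be only part of what the source reports. "The series", "measured", "known", "first", "only" and "open" are said of these compounds alone.

Measured so far in a functional assay on C6 cells (Rattus norvegicus) for cytotoxicity, read by MTT assay, with a stated time of 24 h; a lower number here means a stronger inhibitor, a higher number a weaker inhibitor:
compound 1 `Cc1ccc(-c2cs/c(=N/NC(=O)CSc3nncn3C)n2-c2ccccc2)cc1` gives 56 ug/mL
compound 2 `Cc1ccc(-c2cs/c(=N/NC(=O)CSc3nnnn3C)n2-c2ccccc2)cc1` gives 36.3 ug/mL
compound 3 `Cc1ccc(-c2cs/c(=N/NC(=O)CSc3ncccn3)n2-c2ccccc2)cc1` gives 85 ug/mL

Compound 2 carries the lowest of the three numbers in this assay; the step of a 1.5-fold lower number from compound 1 to compound 2 (0.19 log units; within the scatter) is within the scatter, while the step of a 2.3-fold higher number from compound 2 to compound 3 (0.37 log units; beyond the scatter) is modest and beyond it. Compound 4 `Cn1nnnc1SCC(=O)N/N=c1/scc(-c2ccccc2)n1-c1ccccc1` differs from compound 2 by hydrogen in place of methyl on an aromatic carbon; the same difference, one bond further out, reads 4-methylphenyl to phenyl.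

None of the three measured steps touches this position: all three vary the heterocycle on sulfur. Among the measured compounds shown here, no measured step therefore bears on the change to compound 4, and no step beyond the scatter is expected in this assay, in either direction. Compound 4 is thus estimated near compound 2 at 38 ug/mL, with a range from 18 ug/mL to 80 ug/mL. The expected step is a 1.0-fold higher number from compound 2 to compound 4 (0.02 log units; within the scatter).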

Compound 4, half-maximal inhibitory concentration: 67.7 ug/mL
Beside the measured number, compound 4's estimate is 1.8-fold (0.25 log units) below it; the range from low to high includes it.
By their numbers in this assay, from the lowest: compounds 2, 1, 4 and 3 (each within the scatter of the next, the first and the last beyond it).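

In this assay the aryl position is read for the first time, and 4-methylphenyl to phenyl gives a 1.9-fold higher number from compound 2 to compound 4 (0.27 log units; within the scatter), so on this pair the methyl on the aromatic carbon is not shown to matter beyond the scatter. This rests on one pair, with the 1-methyl-1H-tetrazol-5-yl group on sulfur. No supporting data bear on this result.

As far as these compounds go, whether the same change reads alike with the 4-methyl-4H-1,2,4-triazol-3-yl or pyrimidin-2-yl group on sulfur stays open. So does the outcome with an amine, a carboxylic acid or a longer chain at this place.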